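The source may hold more compounds than are shown below. What is called first, only, known or untested is meant among the compounds shown, and "the series" means these compounds.

Measured compounds:

Compound 1 `Cc1c(F)ccc2cc([C@H](C)Nc3ncnc(N)c3C#N)c(-c3ccccc3)c(=O)n12`: 89%
Compound 2 `C[C@H](Nc1nc(N)ncc1C#N)c1cc2ccc(F)cn2c(=O)c1-c1ccccc1`: 90%
Compound 3 `C[C@H](Nc1nc(N)nc(N)c1C#N)c1cc(=O)n2cc(F)ccc2c1-c1ccc(F)cc1`: "not determined" (no result reported)

In an ADME assay on microsomes from liver (Homo sapiens), read by LC-MS, using NADPH, with a stated time of 30 min, tested at 1 uM (a higher number here means that more of the compound is left, a lower number that less of the compound is left), compound 1 gives 89%, and compound 2 gives 90%. These two values lie within the usual scatter of each other, so nothing separates them. Going by the values given here, for compound 3 the result in this assay is "not determined" (no result reported); where compound 3 stands is therefore unknown, and the only guide is that its two measured relatives keep most of their material over the run.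

Compound 4 `C[C@H](Nc1nc(N)nc(N)c1C#N)c1cc(=O)n2cc(F)ccc2c1-c1cc(F)cc(F)c1` differs from compound 3 in one place: 3,5-difluorophenyl in place of 4-fluorophenyl on an aromatic carbon. In words, a 3,5-difluorophenyl takes the place of a 4-fluorophenyl on an aromatic carbon, while the rest of the shared core stays as it is.

Among the compounds with values here, no measured pair shows what this exchange does in this assay. Within the data shown here, with no such step recorded, and with the two measured relatives sitting high, the expectation is for no change beyond the scatter, in either direction.

Compound 4 is therefore estimated at 85% in this assay, with a range from 65% to 98%.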

Compound 4, percent of the compound remaining: 94%
The estimate for compound 4 lay 9 percentage points below the measured number, within the range that was stated.
By their numbers in this assay, from the lowest: compounds 1, 2 and 4 (each within the scatter of the next).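

In this assay compound 4 gives 94% but compound 3 has no number to set against it, and no step can be read between them. From the compounds shown here alone, what a 3,5-difluorophenyl in place of a 4-fluorophenyl does to the amount of compound left stays open. No supporting data bear on this result.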